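The source may report more compounds than this note shows. Statements on the series, on what has been measured and on what is new or still open speak of the compounds shown alone.

Among the measured compounds shown here, in a functional assay on ZR-75-1 cells (Homo sapiens) for inhibition, read by sulforhodamine B assay (a higher number here means a weaker inhibitor of growth, a lower number a stronger inhibitor of growth), compound 1 `COc1ccc(-c2ccc(-c3ccc(-c4nc5cc(C)ccc5[nH]4)cc3)cc2)cc1OC` gives 3100 nM, the higher of the two numbers measured so far, which makes it the weaker growth inhibitor of the pair. For the measured compounds named here, its only measured neighbour, compound 2 `COc1cc(-c2ccc(-c3ccc(-c4nc5cc(C)ccc5[nH]4)cc3)cc2)cc(OC)c1OC`, gives 190 nM. Adding one methoxy group to the aromatic ring that already carries methoxy groups produced a 16-fold lower number from compound 1 to compound 2 (1.21 log units; beyond the scatter), a large step beyond the usual scatter. A single change on this ring can therefore move the number a long way, at least in this one pair.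

Compound 3 `Cc1ccc2[nH]c(-c3ccc(-c4ccc(-c5ccc(C(F)(F)F)cc5)cc4)cc3)nc2c1` changes the same ring in a different way: 4-(trifluoromethyl)phenyl in place of 3,4-dimethoxyphenyl on an aromatic carbon. The methoxy groups leave and a trifluoromethyl group enters. Going by the values given here, the one measured step bears on this only loosely: it added a methoxy group, whereas compound 3 has none, and no measured compound carries trifluoromethyl. The data therefore point in no clear direction, so the expected change is modest and uncertain, and the estimated step is a 1.6-fold lower number from compound 1 to compound 3 (0.19 log units; within the scatter). For compound 3 the estimated value is 2000 nM, with an expected range from 400 nM to 10000 nM.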

Compound 3, concentration for 50% growth inhibition: 2410 nM
Beside the measured number, compound 3's estimate is 1.2-fold (0.08 log units) below it; low and high end bracket the measured number.
By their numbers in this assay, from the lowest: compound 2; then compounds 3 and 1 (each within the scatter of the next).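

In this assay, 4-(trifluoromethyl)phenyl in place of 3,4-dimethoxyphenyl gives a 1.3-fold lower number from compound 1 to compound 3 (0.11 log units; within the scatter), so this assay does not separate these two compounds even though the groups on the ring are entirely different. The methoxy groups of compound 1 can therefore be lost at this position without a shift beyond the scatter, and the large step seen earlier, a 16-fold lower number from compound 1 to compound 2 (1.21 log units; beyond the scatter), does not extend to every change on this ring. Nothing available here gives a cause for either result.

The compounds shown leave open whether the low number of compound 2, at 190 nM, depends specifically on its pattern of methoxy groups or could also be reached with other groups on this ring. Among the compounds shown here, they also do not show how an amine, a carboxylic acid or a longer alkoxy chain at this position would read, so the range of groups this ring can carry remains uncertain, with only three compounds to go on.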